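From a dichlorophenyl urea to a trifluoromethylphenyl urea

The compounds below may be only part of what the source reports. "The series", "measured", "known", "first", "only" and "open" are said of these compounds alone.

Three compounds have been measured in a functional assay on OVCAR-4 cells (Homo sapiens) for inhibition, read by sulforhodamine B assay, with a stated time of 48 h, tested at 0.1 uM; a lower number here means a stronger effect, a higher number a weaker effect of the compound at the concentration tested:
Compound 1, `COc1cc(Cl)cc(-c2nn(-c3cccc(NC(=O)Nc4ccc(Cl)c(C(F)(F)F)c4)c3)cc2-c2ccncc2)c1`: 97%
Compound 2, `COc1cc(Cl)cc(-c2nn(-c3cccc(NC(=O)Nc4cc(C(F)(F)F)cc(C(F)(F)F)c4)c3)cc2-c2ccncc2)c1`: 97%
Compound 3, `COc1cc(Cl)cc(-c2nn(-c3cccc(NC(=O)Nc4ccc(Cl)c(Cl)c4)c3)cc2-c2ccncc2)c1`: 95%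

All three share one core and differ only in the aryl group on the urea. Compound 3 holds the smallest of the three numbers, but its gap to compound 1 and to compound 2 lies within the scatter, so nothing separates them. The next compound, compound 4, `COc1cc(Cl)cc(-c2nn(-c3cccc(NC(=O)Nc4cccc(C(F)(F)F)c4)c3)cc2-c2ccncc2)c1`, differs from compound 3 by 3-(trifluoromethyl)phenyl in place of 3,4-dichlorophenyl on an amide-type nitrogen. Within the data shown here, the one measured step that touches the same part of the molecule is a number 2 percentage points lower from compound 1 to compound 3 (within the scatter), and it did not move the read-out beyond the scatter. Compound 2, carrying two trifluoromethyl groups, gave a number of the same size. Every variation of this aryl group so far has left the number where it was, and the change toward compound 4 is of the same kind. No step beyond the scatter is therefore expected in this assay, the expected step being a number 1 percentage points higher from compound 3 to compound 4 (within the scatter). Compound 4 is estimated at 96%, between 88% and 100%.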

Compound 4, a percentage reported as activity, at one concentration (the size of the read-out at that concentration, not a potency): 98%
Beside the measured number, compound 4's estimate is 2 percentage points below it, within the range that was stated.
By their numbers in this assay, from the lowest: compounds 3, 1, 2 and 4 (each within the scatter of the next).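

Among these compounds, compound 4 carries only one group on the urea's aryl ring, so it shows what happens when the ring is stripped back. Taking away the chloro (a number 1 percentage points higher from compound 1 to compound 4 (within the scatter)) or one of the two trifluoromethyl groups (a number 1 percentage points higher from compound 2 to compound 4 (within the scatter)) leaves the read-out in this assay within the scatter, and so does replacing 3,4-dichlorophenyl with 3-(trifluoromethyl)phenyl (a number 3 percentage points higher from compound 3 to compound 4 (within the scatter)). A second group on this ring is therefore not needed to keep the number where it stands among these four compounds, and no explanation for this is available from any supporting data.

On these data alone, it remains open whether a bare phenyl ring, or a ring bearing a methoxy group, an amine or a carboxylic acid, would shift the number in this assay. The shared core is identical in all four compounds, so they say nothing about how changes to it would read.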